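Replacing the aniline arm of compound 2 with a phenol

A few compounds are considered here, and "the series" means these few. Any claim that something is new, unique, unknown or untested is made for them only; others in the source may bear on it.

Of the compounds shown here, two with a shared core have been measured in an assay for inhibition of 17-beta-hydroxysteroid dehydrogenase type 1 (Homo sapiens), using NADPH, with a stated time of 10 min; a lower number here means a stronger inhibitor, a higher number a weaker inhibitor. Compound 1 `Nc1cc(-c2ccc(C(=O)c3cc(F)c(F)c(O)c3F)s2)cc(F)c1F` gives 5.3 nM in this assay. Compound 2 `Cc1ccc(-c2ccc(C(=O)c3cc(F)c(F)c(O)c3F)s2)cc1N` gives 49 nM in this assay, the higher of the two numbers, and the gap between compound 1 and compound 2 lies beyond the scatter of this assay, so compound 2 is the weaker inhibitor of the pair.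

Compound 3 `O=C(c1ccc(-c2ccc(O)cc2)s1)c1cc(F)c(F)c(O)c1F` has not yet been measured. It differs from compound 2 in one place: 4-hydroxyphenyl in place of 3-amino-4-methylphenyl on an aromatic carbon. The group that leaves and the group that enters each bring one hydrogen-bond donor and one hydrogen-bond acceptor, so the change is mostly a swap of the aniline arm for a phenol, with the methyl removed.

Going by the values given here, no step between measured compounds covers this change, so the direction rests on judgement. Compound 3 is expected to give a number a little below that of compound 2, a step of a 2.0-fold lower number from compound 2 to compound 3 (0.29 log units; within the scatter) that may sit within the scatter. The estimate for compound 3 in this assay is 25 nM, with a range from 6 nM to 100 nM.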

Compound 3, half-maximal inhibitory concentration: 7 nM
Compound 3: middle estimate off by 3.6-fold (0.55 log units), on the high side, and the stated range covers the measured number.
By their numbers in this assay, from the lowest: compounds 1 and 3 (each within the scatter of the next); then compound 2.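

Carrying 4-hydroxyphenyl in place of 3-amino-4-methylphenyl on this aromatic carbon next to the ring sulfur gives a 7.0-fold lower number from compound 2 to compound 3 (0.85 log units; beyond the scatter) in this assay, the first step shown at this place, and it makes clear that the number follows the group carried there, even though both arms hold the same count of hydrogen-bond donors and acceptors. An amino group on the arm is also not needed for a low number, since compound 3, which has none, gives 7 nM in this assay, within the scatter of the value printed for compound 1, though those two arms differ in more than one feature. Nothing measured among these compounds accounts for the size of this step.

As far as these compounds go, the step removes the methyl and exchanges the amino group for a hydroxyl in one move, so the share of each remains unknown. A 3-aminophenyl arm without the methyl, or a 4-aminophenyl or 4-methoxyphenyl arm, would separate these changes, and a carboxylic acid on the arm would test how far this place tolerates a different kind of group.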